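This account rests on a few compounds, and the source may have more. Where it says the series, first, only, none or still open, it means among the compounds named here.

Measured compounds:
compound 1, `Nc1sc(-c2ccccc2)cc1C(=O)c1ccccc1`: 1%
compound 2, `CN(C)c1ccc(-c2cc(C(=O)c3ccccc3)c(N)s2)cc1`: 29%
compound 3, `Nc1sc(-c2ccc(C(=O)O)cc2)cc1C(=O)c1ccccc1`: 27%

In an assay on CHO cells for positive allosteric modulation of adenosine receptor A1 (Homo sapiens), read by ERK phosphorylation, tested at 10 uM (a lower number here means a stronger effect, a higher number a weaker effect of the compound at the concentration tested), compound 3 stands second highest of the three measured numbers; compound 2 sits within the scatter of it, while compound 1 lies well below, a number 26 percentage points higher from compound 1 to compound 3 (beyond the scatter). Compound 4, `Nc1sc(-c2ccc(C(=O)O)cc2)cc1C(=O)c1ccc(Cl)cc1`, differs from compound 3 by a single change: chloro in place of hydrogen on an aromatic carbon. None of the three measured steps touches this part of the molecule; a number 28 percentage points higher from compound 1 to compound 2 (beyond the scatter) and a number 2 percentage points lower from compound 2 to compound 3 (within the scatter) concern a different aromatic carbon. For the measured compounds named here, no measured step bears directly on this change, so no step beyond the scatter is expected, and compound 4 is expected to stay close to compound 3, no change at the digits printed from compound 3 to compound 4 (within the scatter). Compound 4 is thus estimated at 27%, with a range from 10% to 45%.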

Compound 4, a percentage reported as activity, at one concentration (the size of the read-out at that concentration, not a potency): 29%
For compound 4 the middle estimate is 2 percentage points below the measured one; measured number inside the range.
By their numbers in this assay, from the lowest: compound 1; then compounds 3, 2 and 4 (each within the scatter of the next).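

For the compounds shown here, the earlier steps all changed a different aromatic carbon, so compound 4 gives the first reading on this phenyl ring. In this assay, going from phenyl to 4-chlorophenyl gives a number 2 percentage points higher from compound 3 to compound 4 (within the scatter) and so shows that this position accepts chloro without a step beyond the scatter, with the carboxy group in place. No evidence on the cause of this result is available. From the compounds shown here alone, whether chloro behaves the same way without the carboxy group remains open. So does the effect of another group here, such as methoxy or an amine.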